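Compound 3: a new group on the chain carbon

A few compounds are considered here, and "the series" means these few. Any claim that something is new, unique, unknown or untested is made for them only; others in the source may bear on it.

Going by the values given here, in a functional assay on PC-3 cells (Homo sapiens) for antiproliferative activity, read by MTT assay, with a stated time of 48 h (on this read-out higher numbers stand for weaker inhibition and lower numbers for stronger inhibition), compound 1 (`COc1ccc(CN(C(=O)Cn2cc(CSc3nc4ccccc4s3)nn2)c2cc(OC)c(OC)c(OC)c2)cc1`) gives 28500 nM and compound 2 (`COc1ccc(CN(C(=O)Cn2cc(CSc3nnnn3C)nn2)c2cc(OC)c(OC)c(OC)c2)cc1`) gives 10900 nM, the lower of the two numbers so far. Compound 3 (`COc1ccc(CN(C(=O)Cn2cc(CNS(=O)(=O)c3ccc(Br)cc3)nn2)c2cc(OC)c(OC)c(OC)c2)cc1`) carries ((4-bromophenyl)sulfonyl)amino in place of (1-methyl-1H-tetrazol-5-yl)sulfanyl on a saturated chain carbon bound to an aromatic carbon. Among the compounds with values here, only one measured step bears on this change: a 2.6-fold lower number from compound 1 to compound 2 (0.42 log units; beyond the scatter), modest but beyond the scatter. That step put 1-methyl-1H-tetrazol-5-yl in place of 1,3-benzothiazol-2-yl on a sulfur, whereas the new change replaces the whole group on the chain carbon. It therefore offers a rough size but no direction. The expected change in this assay is a 1.1-fold higher number from compound 2 to compound 3 (0.04 log units; within the scatter), probably not beyond the scatter. Compound 3 is estimated at 12000 nM, with an expected range of 3500 nM to 40000 nM.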

Compound 3, half-maximal inhibitory concentration: 12500 nM
Compound 3: the middle estimate sits 1.0-fold (0.02 log units) below what was measured; the range from low to high includes it.
By their numbers in this assay, from the lowest: compounds 2 and 3 (each within the scatter of the next); then compound 1.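

In this assay, the step at the saturated chain carbon bound to an aromatic carbon is a 1.1-fold higher number from compound 2 to compound 3 (0.06 log units; within the scatter), so the two numbers cannot be told apart even though the whole group differs: ((4-bromophenyl)sulfonyl)amino brings a six-membered aromatic ring of carbon only and a hydrogen-bond donor, which (1-methyl-1H-tetrazol-5-yl)sulfanyl lacks. The new group also gives a 2.3-fold lower number from compound 1 to compound 3 (0.36 log units; beyond the scatter), so of the three groups at this place, only (1,3-benzothiazol-2-yl)sulfanyl stands apart from the other two beyond the scatter. Nothing available explains these steps.

From the compounds shown here alone, it remains open how much of the result depends on the bromine of ((4-bromophenyl)sulfonyl)amino, which a plain phenylsulfonylamino or a 4-methoxyphenylsulfonylamino group would test. A simple amine or a carboxylic acid on the chain carbon would show whether an aromatic ring is needed there at all.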